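Swapping the aryl group on the carbonyl of a weak cytotoxin

The source may report more compounds than this note shows. Statements on the series, on what has been measured and on what is new or still open speak of the compounds shown alone.

Compound 1 `COc1cc(-c2nnc3n2NC(c2ccco2)C(C(=O)c2cccc4ccccc24)S3)cc(OC)c1OC` and compound 2 `COc1cc(-c2nnc3n2NC(c2ccco2)C(C(=O)c2ccc(C(F)(F)F)cc2)S3)cc(OC)c1OC` share one core and differ only in the group on a carbonyl carbon. In a functional assay on HepG2 cells (Homo sapiens) for cytotoxicity, read by MTT assay, with a stated time of 48 h (on this read-out higher numbers stand for weaker inhibition and lower numbers for stronger inhibition), compound 1 gives 33900 nM. For compound 2 this assay reports only a limit, > 100000 nM. The change from naphthalen-1-yl to 4-(trifluoromethyl)phenyl thus produced an at least 2.9-fold higher number from compound 1 to compound 2 (0.46 log units; beyond the scatter), a step that is open-ended at the limit of > 100000 nM in this assay, at which 1 of the 2 values shown sits. Compound 3 `COc1cc(-c2nnc3n2NC(c2ccco2)C(C(=O)c2cccc(Br)c2)S3)cc(OC)c1OC` has not been measured. It differs from compound 2 by 3-bromophenyl in place of 4-(trifluoromethyl)phenyl on a carbonyl carbon. Within the data shown here, the one measured step bears only loosely on this change, since it swaps a different pair of groups at the same place; it shows that a changed aryl group on that carbonyl can leave the compound at the limit. Compound 3 is therefore expected to stay near that limit, with an at least 1.2-fold lower number from compound 2 to compound 3 (0.09 log units; that floor lies within the scatter) expected to be small. The estimate for compound 3 is 80000 nM, ranging from 25000 nM to 250000 nM.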

Compound 3, half-maximal inhibitory concentration: > 100000 nM
Compound 3 ended at the assay's limit (the forecaster's own chance of this, stated with the estimate: 55%); middle value at least 1.2-fold (0.09 log units) from the limit.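

In this assay compound 3 gives > 100000 nM, which is a limit of the assay and not a number, so a second substituted phenyl group on the carbonyl ends at the same limit as the first. Replacing naphthalen-1-yl with 3-bromophenyl gives an at least 2.9-fold higher number from compound 1 to compound 3 (0.46 log units; beyond the scatter), which leaves compound 1 as the only one of the three with a readable value. Compound 2 and compound 3 both sit at the limit, so the step between them cannot be read, and 3-bromophenyl and 4-(trifluoromethyl)phenyl cannot be ranked: the limit of > 100000 nM in this assay, at which 2 of the 3 values shown sit.

Going by these compounds, it remains open how far the true values of compound 2 and compound 3 lie beyond the limit. On these data alone, it is also open whether plain phenyl or naphthalen-2-yl on the same carbonyl would give a readable value, as naphthalen-1-yl does.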